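Remote Aryl Substituent Swap Expected to Leave Acidity Unchanged

This account rests on a few compounds, and the source may have more. Where it says the series, first, only, none or still open, it means among the compounds named here.

Compound 3 `COc1ccc(-c2ccc3c(NCCCNCc4cccc(OC)c4O)ccnc3c2)cc1` gives 9.47 in a physicochemical assay for acid dissociation, level with compound 1 `COc1cccc(CNCCCNc2ccnc3cc(Cc4ccccc4)ccc23)c1O` at 9.47 and with compound 2 `COc1cccc(CNCCCNc2ccnc3cc(CC4CCCCC4)ccc23)c1O` at 9.47. Compound 4 `COc1cccc(CNCCCNc2ccnc3cc(-c4ccc(C(C)(C)C)cc4)ccc23)c1O` differs from compound 3 by tert-butyl in place of methoxy on an aromatic carbon; read one bond further out, this is 4-methoxyphenyl to 4-(tert-butyl)phenyl. All three measured steps concern replacements on that same aromatic carbon of the shared core, and each stayed within the scatter: no change at the digits printed from compound 1 to compound 2 (within the scatter), no change at the digits printed from compound 1 to compound 3 (within the scatter) and no change at the digits printed from compound 2 to compound 3 (within the scatter). Since every variation there left this assay unmoved, the expected step is no change at the digits printed from compound 3 to compound 4 (within the scatter), nothing beyond the scatter in either direction. Compound 4 is therefore estimated at 9.47, with a range from 9.2 to 9.75.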

Compound 4, acid dissociation constant: 9.47
Beside the measured number, compound 4's estimate shows no gap at the digits printed; the measured number falls inside the stated range.
By their numbers in this assay, from the lowest: compounds 1, 2, 3 and 4 (each within the scatter of the next).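

In this assay, methoxy, with 2 heavy atoms and 1 hydrogen-bond acceptor, gives way to tert-butyl, with 4 heavy atoms and 0 hydrogen-bond acceptors, and the result is no change at the digits printed from compound 3 to compound 4 (within the scatter), so this position now tolerates a change in the terminal group of the aryl substituent as well. The reading also holds for 4-(tert-butyl)phenyl, with no change at the digits printed from compound 2 to compound 4 (within the scatter) and no change at the digits printed from compound 1 to compound 4 (within the scatter). No independent evidence bears on this result. On these data alone, whether an amine or a carboxylic acid on this aromatic carbon would leave this assay equally unmoved remains open, as does the effect of a longer chain elsewhere in the molecule.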